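Bromo-to-hydrogen swap on the coumarin bearing triazole series

This account rests on a few compounds, and the source may have more. Where it says the series, first, only, none or still open, it means among the compounds named here.

Measured so far:
compound 1 `NCCC(=O)N1Cc2ccccc2-c2nnn(-c3cc4cc(Br)ccc4oc3=O)c2-c2ccccc21` — 10700 nM
compound 2 `NCCC(=O)N1Cc2ccccc2-c2nnn(-c3cc4cc(Cl)cc(Cl)c4oc3=O)c2-c2ccccc21` — 9830 nM

In a functional assay on MCF7 cells (Homo sapiens) for cytotoxicity, read by MTT assay, with a stated time of 24 h (on this read-out higher numbers stand for weaker inhibition and lower numbers for stronger inhibition), compound 1 gives 10700 nM, the highest of the two numbers; compound 2 gives 9830 nM, and the two lie within the scatter of one another, so no order is claimed between them. Compound 3 `NCCC(=O)N1Cc2ccccc2-c2nnn(-c3cc4ccccc4oc3=O)c2-c2ccccc21` differs from compound 1 by hydrogen in place of bromo on an aromatic carbon. Within the data shown here, no step between measured compounds bears on this change, so the step is estimated as small, toward a higher number, and at best borderline to the scatter. Compound 3 is expected to give 15000 nM, within a range of 7000 nM to 35000 nM. The expected step is a 1.4-fold higher number from compound 1 to compound 3 (0.15 log units; within the scatter).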

Compound 3, half-maximal inhibitory concentration: 12700 nM
The estimate for compound 3 lay 1.2-fold (0.07 log units) above the measured number; low and high end bracket the measured number.
By their numbers in this assay, from the lowest: compounds 2, 1 and 3 (each within the scatter of the next).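

In this assay, hydrogen in place of bromo on this aromatic carbon leaves a 1.2-fold higher number from compound 1 to compound 3 (0.07 log units; within the scatter) as the whole effect of the swap. The bromo group is therefore not required at this place for a number in this range, and this single change opens no step beyond the scatter. Nothing at hand bears on the reason for this result.

Still open, on these data alone, is whether an amine or a carboxylic acid at this aromatic carbon would shift the number beyond the scatter. The same question stands for a methoxy group there.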